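Ring size of the amino heterocycle and hepatocyte clearance

The source may hold more compounds than are shown below. What is called first, only, known or untested is meant among the compounds shown, and "the series" means these compounds.

Compound 2 `CC(=O)Nc1cc(Nc2cc(NC3CC3)n3ncc(C#N)c3n2)ccc1N1CC[C@@H](N)C1` stands level with compound 1 `CC(=O)Nc1cc(Nc2cc(NC3CC3)n3ncc(C#N)c3n2)ccc1N1CC[C@H](N(C)C)C1` in an ADME assay on cells (Hepatocyte, Rattus norvegicus) for metabolic stability; on this read-out higher numbers stand for fast clearance and lower numbers for slow clearance: compound 1 gives 2.5 uL/min and compound 2 gives 2.5 uL/min, and no change at the digits printed from compound 1 to compound 2 (within the scatter). Compound 3 `CC(=O)Nc1cc(Nc2cc(NC3CC3)n3ncc(C#N)c3n2)ccc1N1CCC[C@@H](N)C1` differs from compound 2 by 3-aminopiperidin-1-yl in place of 3-aminopyrrolidin-1-yl on an aromatic carbon. Going by the values given here, the only measured step altered the group on the same aromatic carbon and stayed within the scatter, so for the move from a five-membered to a six-membered non-aromatic ring no step beyond the scatter is expected in this assay, that is no change at the digits printed from compound 2 to compound 3 (within the scatter). Compound 3 is therefore estimated at 2.5 uL/min, with a range from 1.2 uL/min to 5 uL/min.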

Compound 3, intrinsic clearance in a liver preparation (reported as CLH), per the amount of preparation that the assay uses in the Hepatocyte assay: < 1 uL/min
Compound 3 ended at the assay's limit; the forecaster's own chance of this, stated with the estimate: 5%; at least 2.5-fold (0.39 log units) between middle value and limit.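

In the Hepatocyte assay, the six-membered ring at this aromatic carbon gives a step beyond the scatter, an at least 2.5-fold lower number from compound 2 to compound 3 (0.39 log units; beyond the scatter), and likewise an at least 2.5-fold lower number from compound 1 to compound 3 (0.39 log units; beyond the scatter), whereas the earlier change on the five-membered ring did not. In a physicochemical assay for solubility, read by LC-MS, in phosphate buffer, with a stated time of 24 h, at pH 7.4 (on this read-out lower numbers stand for lower solubility and higher numbers for higher solubility), compound 2 gives 812000 nM, and an at least 1.2-fold higher number from compound 2 to compound 3 (0.09 log units; that floor lies within the scatter), so no gain can be claimed. In the physicochemical assay compound 3 gives > 1000000 nM, which is a limit, and its clearance reading is also a limit.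

As far as these compounds go, the true values of compound 3 in both assays remain open. So does whether 3-(dimethylamino)piperidin-1-yl or a seven-membered azepane ring would follow compound 3 in the Hepatocyte assay.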